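From 2-bromophenyl to 2,3-dichlorophenyl on the shared core

The compounds below may be only part of what the source reports. "The series", "measured", "known", "first", "only" and "open" are said of these compounds alone.

In a functional assay on MCF7 cells (Homo sapiens) for inhibition, read by MTT assay, with a stated time of 48 h, tested at 10 uM (on this read-out lower numbers stand for less inhibition of growth and higher numbers for more inhibition of growth at the one concentration tested), compound 1 `Cc1cc(=O)c2c(O)c(CN3CCC(Cc4ccccc4)CC3)c(O)c([C@H]3CCN(C)C[C@H]3O)c2o1` gives 17% and compound 2 `Cc1cc(=O)c2c(O)c(CN(C)CC(=O)O)c(O)c([C@H]3CCN(C)C[C@H]3O)c2o1` gives 27% while compound 3 `Cc1oc2c([C@H]3CCN(C)C[C@H]3O)c(O)cc(O)c2c(=O)c1C(O)c1ccccc1Br` gives 21% as its reading. Compound 3 thus stands within the usual scatter of both other compounds, so these three numbers set no order among them. Compound 4 `Cc1oc2c([C@H]3CCN(C)C[C@H]3O)c(O)cc(O)c2c(=O)c1C(O)c1cccc(Cl)c1Cl` is still unmeasured. It has 2,3-dichlorophenyl in place of 2-bromophenyl on a saturated chain carbon bound to an aromatic carbon and an oxygen on a saturated carbon. Going by the values given here, no two measured compounds differ in one place only, so no measured step sizes this swap. In this assay no step beyond the scatter is expected, the estimated step being a number 3 percentage points higher from compound 3 to compound 4 (within the scatter) and nothing larger. Compound 4 is expected at 24% with an estimated range from 11% to 40% for its reading.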

Compound 4, percent growth inhibition at one concentration: 7%
The estimate for compound 4 lay 17 percentage points above the measured number; the measured number lies below the stated range.
By their numbers in this assay, from the lowest: compounds 4, 1, 3 and 2 (each within the scatter of the next, the first and the last beyond it).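

In this assay, the group on this saturated chain carbon proves able to shift the reading: replacing 2-bromophenyl with 2,3-dichlorophenyl gives a number 14 percentage points lower from compound 3 to compound 4 (beyond the scatter). Going by these compounds alone, this is the first one-place step available for the series, and it means less inhibition of growth at the one concentration tested. Nothing measured here accounts for the drop. The swap from bromine to chlorine and the gain of a second chlorine arrive together, so their shares cannot be separated. As far as these compounds go, how a plain phenyl or a pyridine ring would read at this place remains open.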